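The source may report more compounds than this note shows. Statements on the series, on what has been measured and on what is new or still open speak of the compounds shown alone.

Compound 2 `CCCc1ccc(N2C(=O)NC3(CSC4=C3C(=O)c3ncccc3C4=O)C2=O)cc1` is the reference point of this set. In a functional assay on MCF7 cells (Homo sapiens) for antiproliferative activity, read by MTT assay, with a stated time of 96 h (a lower number here means a stronger inhibitor, a higher number a weaker inhibitor), compound 2 gives 2 nM, the lowest of the three numbers in hand; compound 1 `CN(C)c1ccc(N2C(=O)NC3(CSC4=C3C(=O)c3ncccc3C4=O)C2=O)cc1` gives 10 nM, and compound 3 `O=C1NNC(=O)C2(CSC3=C2C(=O)c2ncccc2C3=O)N1` gives 1250 nM. Going by the values given here, the only single-site step measured is a 5.0-fold lower number from compound 1 to compound 2 (0.70 log units; beyond the scatter), a swap on the same aromatic carbon that is changed again here. Compound 4 `O=C1C2=C(C(=O)c3ncccc31)C1(CS2)NC(=O)N(c2ccc([N+](=O)[O-])cc2)C1=O` differs from compound 2 by nitro in place of propyl on an aromatic carbon. That one step shows the position bears a change of this size with a modest shift, so a step of comparable size in either direction, more likely toward a higher number, is expected; the estimate for compound 4 is 6 nM in this assay, within 1.5 nM to 25 nM, i.e. a 3.0-fold higher number from compound 2 to compound 4 (0.48 log units; beyond the scatter) expected.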

Compound 4, half-maximal inhibitory concentration: 350 nM
For compound 4 the middle estimate is 58-fold (1.77 log units) below the measured one; measured number outside the range, above it.
By their numbers in this assay, from the lowest: compound 2; then compound 1; then compound 4; then compound 3.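

In this assay, nitro in place of propyl gives a 180-fold higher number from compound 2 to compound 4 (2.24 log units; beyond the scatter), and nitro in place of dimethylamino gives a 35-fold higher number from compound 1 to compound 4 (1.54 log units; beyond the scatter). The group on this aromatic carbon can therefore move the number much further than the earlier swap suggested, which was only a 5.0-fold lower number from compound 1 to compound 2 (0.70 log units; beyond the scatter), and 4-nitrophenyl stands well apart from 4-propylphenyl. No measured property is available to account for the nitro result. Still open, from the compounds shown here alone, is how other groups behave at this place, such as a carboxylic acid, a methoxy group or a longer chain like pentyl.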